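A few compounds are considered here, and "the series" means these few. Any claim that something is new, unique, unknown or untested is made for them only; others in the source may bear on it.

Measured compounds:
Compound 1, `O=C1C[C@H](OCc2cn(Cc3ccccc3)nn2)[C@H]2CO[C@@H]1O2`: in a functional assay on MDA-MB-231 cells (Homo sapiens) for cytotoxicity, read by MTT assay, with a stated time of 48 h (a higher number here means a weaker inhibitor, a lower number a stronger inhibitor), compound 1 reaches only the assay limit of > 50000 nM.
Compound 2, `COC(=O)Cn1cc(CO[C@H]2CC(=O)[C@@H]3OC[C@H]2O3)nn1`: in this assay compound 2 gives 21300 nM.

Going by the values given here, compound 2 thus holds the only real number here; the other value, (the limit of > 50000 nM in this assay, at which 1 of the 2 values shown sits), is a limit rather than a measurement. Compound 3, `O=C1C[C@H](OCc2cn(C(=O)c3ccccc3)nn2)[C@H]2CO[C@@H]1O2`, differs from compound 2 in one place: benzoyl in place of (methoxycarbonyl)methyl on an aromatic nitrogen. Among the compounds with values here, the single measured step bears on this only loosely: an at least 2.3-fold lower number from compound 1 to compound 2 (0.37 log units; beyond the scatter), a change in which the phenyl ring left and methoxycarbonyl came in. Compound 3 reverses part of that, bringing a phenyl ring back in the form of benzoyl while the methoxycarbonyl leaves, so a step back toward the weaker side of roughly that size is expected, a 1.9-fold higher number from compound 2 to compound 3 (0.27 log units; within the scatter). For compound 3 the estimate in this assay is therefore 40000 nM, with a range from 12000 nM to 130000 nM and a fair chance that only a limit is reported.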

Compound 3, half-maximal inhibitory concentration: 25900 nM
Compound 3: the middle estimate sits 1.5-fold (0.19 log units) above what was measured; the measured number falls inside the stated range.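

Benzoyl and (methoxycarbonyl)methyl on this aromatic nitrogen cannot be told apart in this assay, with a 1.2-fold higher number from compound 2 to compound 3 (0.08 log units; within the scatter); compound 3 carries a phenyl ring within its benzoyl group and still stands level with compound 2, which has no phenyl ring. The change from benzyl to benzoyl gives an at least 1.9-fold lower number from compound 1 to compound 3 (0.28 log units; that floor lies within the scatter), so the floor of this step does not by itself establish a real gain. The true size of that step cannot be read, since compound 1 remains a limit rather than a number: the limit of > 50000 nM in this assay, at which 1 of the 3 values shown sits.

Going by these compounds, it remains open whether a carboxylic acid in place of the methoxycarbonyl, an amine, or a longer chain on this aromatic nitrogen would shift the number beyond the scatter. Also open, on these data alone, is how a benzoyl group carrying an amine on its phenyl ring would read.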